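From thiophen-2-yl to 1H-pyrrol-2-yl on a shared core

The source may report more compounds than this note shows. Statements on the series, on what has been measured and on what is new or still open speak of the compounds shown alone.

Compound 1 `O=C(Nc1ccc(-c2ccoc2)cc1)C1CCCN(Cc2ccc(F)c(F)c2)C1`: 3000 nM
Compound 2 `O=C(Nc1ccc(-c2cccs2)cc1)C1CCCN(Cc2ccc(F)c(F)c2)C1`: 530 nM

Going by the values given here, in a functional assay on A-375 cells (Homo sapiens) for activation, with a stated time of 3 days (a lower number here means that less compound is needed, a higher number that more compound is needed for the effect), compound 2 gives 530 nM, the lowest of the two numbers measured so far. Among the compounds with values here, its only neighbour is compound 1 at 3000 nM.

Compound 3 `O=C(Nc1ccc(-c2ccc[nH]2)cc1)C1CCCN(Cc2ccc(F)c(F)c2)C1` keeps the shared core of compound 2 and has 1H-pyrrol-2-yl in place of thiophen-2-yl on an aromatic carbon.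

Within the data shown here, one measured step bears on this change. It is a 5.7-fold lower number from compound 1 to compound 2 (0.75 log units; beyond the scatter), a modest but real move that came with thiophen-2-yl in place of furan-3-yl at the same place. It shows that exchanging one five-membered aromatic ring for another can shift the number in this assay. Among the measured compounds shown here, no measured compound carries 1H-pyrrol-2-yl, so the direction remains uncertain.

A step no larger than that one seems likely, and a move toward a higher number is expected, given that compound 2 at 530 nM is the lower of the two values. The estimate amounts to a 2.5-fold higher number from compound 2 to compound 3 (0.39 log units; beyond the scatter), which is an expected step. For compound 3 the expected value is 1300 nM, with an estimated range of 400 nM to 4000 nM.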

Compound 3, half-maximal effective concentration: 720 nM
Estimate against measurement, compound 3: 1.8-fold (0.26 log units) above, and the stated range covers the measured number.
By their numbers in this assay, from the lowest: compounds 2 and 3 (each within the scatter of the next); then compound 1.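

In this assay, the step of a 1.4-fold higher number from compound 2 to compound 3 (0.13 log units; within the scatter) shows that, on this aromatic carbon para to a large group, 1H-pyrrol-2-yl and thiophen-2-yl cannot be told apart, even though the swap exchanges sulfur for nitrogen and adds a hydrogen-bond donor. The step of a 4.2-fold lower number from compound 1 to compound 3 (0.62 log units; beyond the scatter) is beyond the scatter, so compound 1 with furan-3-yl now stands apart from both compounds carrying a ring joined through its 2-position, not only from compound 2. With just these three compounds, the ring's hetero atom and its point of attachment change together in compound 1, and no measurement at hand accounts for any of these differences.

Going by these compounds, all three compounds carry a five-membered aromatic ring with one hetero atom at this place, so it remains open how a plain phenyl, a pyridine or a non-aromatic group such as an amine would read in this assay. Furan-2-yl would be especially informative, since it would keep the furan ring but join it through the same position as the other two rings, separating the effect of the hetero atom from that of the attachment point.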